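The compounds below may be only part of what the source reports. "The series", "measured", "known", "first", "only" and "open" are said of these compounds alone.

Working notes on the series. Three compounds have numbers in a functional assay on COLO 205 cells (Homo sapiens) for inhibition, read by sulforhodamine B assay, tested at 100 uM; a higher number here means more inhibition of growth at the concentration tested, a lower number less inhibition of growth. Compound 1 `COc1cc(C2CC(c3ccc(OCc4cn(Cc5ccc([N+](=O)[O-])cc5)nn4)cc3)=NN2C(C)=O)ccc1Oc1cn(Cc2ccc([N+](=O)[O-])cc2)nn1` gives 51%. Compound 2 `COc1cc(C2CC(c3ccc([N+](=O)[O-])cc3)=NN2C(C)=O)ccc1OCc1cn(Cc2ccc([N+](=O)[O-])cc2)nn1` gives 85%. Compound 3 `COc1cc(C2CC(c3cc(OC)c(OC)c(OC)c3)=NN2C(C)=O)ccc1OCc1cn(Cc2ccc([N+](=O)[O-])cc2)nn1` gives 99%, the highest of the three numbers: compound 2 lies nearest, a step below it beyond the scatter, and compound 1 lies furthest, also beyond the scatter. Among the compounds with values here, the one single-place step among the measured compounds is a number 14 percentage points higher from compound 2 to compound 3 (beyond the scatter), a swap of the aryl group on the carbon with a double bond to nitrogen.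

Compound 4 `COc1cc(C2CC(c3cccc4ccccc34)=NN2C(C)=O)ccc1OCc1cn(Cc2ccc([N+](=O)[O-])cc2)nn1` has not been measured in this assay. It differs from compound 3 in naphthalen-1-yl in place of 3,4,5-trimethoxyphenyl on a carbon with a double bond to nitrogen. This is a change at the same position as the measured step, so the step from compound 2 to compound 3 is the only one that bears on it; its size was modest and beyond the scatter, and that swap involved a change of acceptor count of the same kind. Naphthalen-1-yl has no measured precedent here, so the direction is uncertain; since compound 3 sits near the top of the scale, the room upward is small, and a modest step downward, beyond the scatter, is expected for compound 4 as a number 15 percentage points lower from compound 3 to compound 4 (beyond the scatter). The estimate for compound 4 in this assay is 84%, with a range from 62% to 98%.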

Compound 4, percent growth inhibition at one concentration: 72%
Estimate against measurement, compound 4: 12 percentage points above; the measured number falls inside the stated range.
By their numbers in this assay, from the lowest: compound 1; then compound 4; then compound 2; then compound 3.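

At the carbon with a double bond to nitrogen, a third aryl group gives two further steps in this assay: a number 27 percentage points lower from compound 3 to compound 4 (beyond the scatter) and a number 13 percentage points lower from compound 2 to compound 4 (beyond the scatter), both modest and beyond the scatter. Together with a number 14 percentage points higher from compound 2 to compound 3 (beyond the scatter), this places the three groups in one order at this position, with 3,4,5-trimethoxyphenyl highest, 4-nitrophenyl in the middle and naphthalen-1-yl lowest, so the swap of aryl group changes the number in every pair and a second fused carbon ring does not match either single-ring group. Nothing available explains this order.

The three groups differ in several ways at once, so the compounds shown cannot separate the part played by ring count, heavy atoms or hydrogen-bond acceptors, and a phenyl ring bearing a single methoxy group, an amine or a carboxylic acid would help to pull these apart. Naphthalen-2-yl would show whether the point of attachment of the fused ring system matters, and a read-out at one concentration leaves open how the order would look across a range of concentrations.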